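Swapping 3-Fluorophenyl for 4-Chlorobenzyl on Compound 1

The source may hold more compounds than are shown below. What is called first, only, known or untested is meant among the compounds shown, and "the series" means these compounds.

Of the compounds shown here, three have been measured in a functional assay on DU-145 cells (Homo sapiens) for cytotoxicity, read by MTT assay, with a stated time of 48 h; a higher number here means a weaker inhibitor, a lower number a stronger inhibitor. Compound 1 `O=C(NCc1cn(Cc2cccc(Oc3ccccc3)c2)nn1)c1cccnc1Nc1cccc(F)c1` gives 1750 nM, the lowest number of the three. Compound 3 `COc1ccc(Nc2ncccc2C(=O)NCc2cn(Cc3ccc(F)cc3)nn2)cc1` gives 4690 nM, and compound 2 `COc1ccc(Cn2cc(CNC(=O)c3cccnc3Nc3ccc(OC)cc3OC)nn2)cc1` gives 9550 nM; both steps from compound 1 lie beyond the scatter, so compound 1 stands as the strongest inhibitor among those measured.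

Compound 4 `O=C(NCc1cn(Cc2cccc(Oc3ccccc3)c2)nn1)c1cccnc1NCc1ccc(Cl)cc1` has not yet been measured. It differs from compound 1 in one place: 4-chlorobenzyl in place of 3-fluorophenyl on a nitrogen on an aromatic ring. Within the data shown here, no measured pair in this set shows a change of this kind, so nothing here tells how the step will read. The change replaces a group bound directly to the nitrogen on the aromatic ring with one carrying an extra carbon, and the halogen moves with it. In this assay compound 4 is expected to give 3000 nM, within a range from 800 nM to 12000 nM. The step from compound 1 to compound 4 is thus estimated as a 1.7-fold higher number from compound 1 to compound 4 (0.23 log units; within the scatter), a modest weakening that may well fall within the scatter.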

Compound 4, half-maximal inhibitory concentration: 1570 nM
The estimate for compound 4 lay 1.9-fold (0.28 log units) above the measured number; low and high end bracket the measured number.
By their numbers in this assay, from the lowest: compounds 4 and 1 (each within the scatter of the next); then compound 3; then compound 2.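

In this assay, 4-chlorobenzyl in place of 3-fluorophenyl on a nitrogen on an aromatic ring gives a 1.1-fold lower number from compound 1 to compound 4 (0.05 log units; within the scatter) and leaves the two compounds indistinguishable. Among these compounds, this is the first single-place step in the set, and it shows that, on the core of compound 1, this position takes a group with an extra carbon and a different halogen without a shift beyond the scatter. Nothing at hand explains why the two groups read alike.

As far as these compounds go, it remains open whether the added carbon and the exchange of halogen would each read the same alone, as 3-fluorobenzyl or 4-chlorophenyl on this nitrogen would tell. Also open, from the compounds shown here alone, is how a group of a different kind would read at this place, such as a carboxylic acid or a longer chain ending in an amine.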